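Expected Cytotoxicity of a Benzylsulfanyl Replacement

This account rests on a few compounds, and the source may have more. Where it says the series, first, only, none or still open, it means among the compounds named here.

For the measured compounds named here, compound 1 `Nc1nc(NC2CC2)c2ncn(/C=C3/CC3(CO)CO)c2n1` is one of two compounds so far measured in an ADME assay on CCRF-HSB-2 cells (Homo sapiens) for cytotoxicity, with a stated time of 7 days; a higher number here means that more compound is tolerated, a lower number that less compound is tolerated. In this assay compound 1 gives > 20000 nM, which is a limit of the assay rather than a number. Compound 2 `CCCCCCOc1nc(N)nc2c1ncn2/C=C1/CC1(CO)CO` carries hexyloxy in place of cyclopropylamino on an aromatic carbon. In this assay compound 2 gives > 20000 nM, again a limit. The step that the two limits leave unreadable from compound 1 to compound 2 thus has no readable size, as both values sit at the limit of > 20000 nM in this assay, at which 2 of the 2 values shown sit.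

Compound 3 `Nc1nc(SCc2ccccc2)c2ncn(/C=C3/CC3(CO)CO)c2n1` differs from compound 1 by benzylsulfanyl in place of cyclopropylamino on an aromatic carbon. Going by the values given here, the only measured step, a step that the two limits leave unreadable from compound 1 to compound 2, bears on a change at the same aromatic carbon, yet its size cannot be read, so it gives no direction for the new change. With both known values sitting at the limit, compound 3 is expected to be tolerated in a similar way, and the expected step that the limit leaves unreadable from compound 1 to compound 3 is none beyond the scatter. The estimate for compound 3 in this assay is 25000 nM, with a range from 8000 nM to 60000 nM.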

Compound 3, half-maximal cytotoxic concentration: > 100000 nM
Compound 3: a limit, no number (the forecaster's own chance of this, stated with the estimate: 65%); middle value at least 4.0-fold (0.60 log units) away from the limit.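

In this assay compound 3 gives > 100000 nM, a limit of the assay and not a number. For the compounds shown here, compound 1 and compound 2 also stand at limits, so no step among the three compounds can be read. The compounds shown leave open whether cyclopropylamino, hexyloxy and benzylsulfanyl on this aromatic carbon differ in how well they are tolerated.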